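The compounds below may be only part of what the source reports. "The series", "measured", "known", "first", "only" and "open" are said of these compounds alone.

Compound 1 `COc1cc2c(Oc3ccc(NC(=O)N/N=C/c4ccc(O)cc4)cc3F)ccnc2cc1OCCCN1CCCCC1` gives 790 nM in a functional assay on MDA-MB-231 cells (Homo sapiens) for cytotoxicity, read by MTT assay, with a stated time of 72 h; on this read-out higher numbers stand for weaker inhibition and lower numbers for stronger inhibition. Compound 2 `COc1cc2c(Oc3ccc(NC(=S)N/N=C/c4ccccc4)cc3F)ccnc2cc1OCCCN1CCCCC1` gives 1200 nM in this assay.

Those two values sit within the scatter of each other, as the step of a 1.5-fold higher number from compound 1 to compound 2 (0.18 log units; within the scatter) shows. Compound 3 `COc1cc2c(Oc3ccc(NC(=S)N/N=C/c4ccc(F)c(F)c4)cc3F)ccnc2cc1OCCCN1CCCCC1` is yet to be measured; it carries 3,4-difluorophenyl in place of phenyl on a carbon with a double bond to nitrogen. Within the data shown here, no measured step touches that phenyl ring, so the only guide is that the single step from compound 1 to compound 2 stayed within the scatter. The expectation for compound 3 is therefore a step of a 1.2-fold lower number from compound 2 to compound 3 (0.08 log units; within the scatter), nothing beyond the scatter. Compound 3 is estimated at 1000 nM, within 400 nM to 2500 nM.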

Compound 3, half-maximal inhibitory concentration: 1400 nM
For compound 3 the middle estimate is 1.4-fold (0.15 log units) below the measured one, and the stated range covers the measured number.
By their numbers in this assay, from the lowest: compounds 1, 2 and 3 (each within the scatter of the next).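

Putting 3,4-difluorophenyl in place of phenyl on a carbon with a double bond to nitrogen gives a 1.2-fold higher number from compound 2 to compound 3 (0.07 log units; within the scatter) in this assay for the first change shown at this position. The two added fluorine atoms therefore leave the result within the scatter in this test. Nothing measured here offers an explanation for this result.

From the compounds shown here alone, it remains open whether an amine or a carboxylic acid on this phenyl ring would give a step beyond the scatter. Going by these compounds, whether a single fluorine would behave the same way also remains open.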